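Methoxy to hydroxy: what to expect of compound 3

This account rests on a few compounds, and the source may have more. Where it says the series, first, only, none or still open, it means among the compounds named here.

In a functional assay on RL cells (Homo sapiens) for cytotoxicity, with a stated time of 48 h (on this read-out higher numbers stand for weaker inhibition and lower numbers for stronger inhibition), compound 1 (`COc1cccc(/C=C/C(=O)c2c(OC)cc(OC)cc2OC)c1`) gives 5900 nM and compound 2 (`COc1cc(OC)c(C(=O)/C=C/c2ccc(Br)cc2)c(OC)c1`) gives 8300 nM, so the two sit within the usual scatter of each other. Compound 3 (`COc1cccc(/C=C/C(=O)c2c(O)cc(OC)cc2OC)c1`) differs from compound 1 by hydrogen in place of methyl on an oxygen on an aromatic ring: methoxy to hydroxy. Among the measured compounds shown here, the only measured step, a 1.4-fold higher number from compound 1 to compound 2 (0.15 log units; within the scatter), is a small one and concerns a different place in the structure, so it offers only weak guidance. No step beyond the scatter is therefore expected in this assay, and the estimated step is a 1.2-fold lower number from compound 1 to compound 3 (0.07 log units; within the scatter). For compound 3 the expected value is 5000 nM, with an estimated range of 1800 nM to 14000 nM.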

Compound 3, half-maximal inhibitory concentration: 9000 nM
Compound 3: the middle estimate sits 1.8-fold (0.26 log units) below what was measured; measured number inside the range.
By their numbers in this assay, from the lowest: compounds 1, 2 and 3 (each within the scatter of the next).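

At this place, on an oxygen on an aromatic ring, hydrogen in place of methyl gives a 1.5-fold higher number from compound 1 to compound 3 (0.18 log units; within the scatter) in this assay and so moves the number no further than the usual scatter. Methoxy to hydroxy at this one oxygen therefore shows no clear effect on the read-out, a result the earlier pair, which differs at another place, could not give. Nothing available here explains this result. Still open, from the compounds shown here alone, is how a longer chain on this oxygen, such as ethyl, or an amine in its place would read.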